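This account rests on a few compounds, and the source may have more. Where it says the series, first, only, none or still open, it means among the compounds named here.

In a functional assay on EBC-1 cells (Homo sapiens) for antiproliferative activity, with a stated time of 72 h (a higher number here means a weaker inhibitor, a lower number a stronger inhibitor), compound 1 (`N#Cc1ccc(-c2cc(F)c3ncc(Cc4ccc5ncccc5c4)n3c2)cn1`) gives 189 nM and compound 2 (`N#Cc1cccc(-c2cc(F)c3ncc(Cc4ccc5ncccc5c4)n3c2)c1`) gives 107 nM as its value. These two numbers lie within the usual scatter of each other, so neither compound can be ranked ahead. Compound 3 (`CCO/N=C(\C)c1cc(F)c2ncc(Cc3ccc4ncccc4c3)n2c1`) keeps the core of compound 2 and changes one group: a group of 6 heavy atoms (4 carbon, 1 nitrogen, 1 oxygen; no ring) in place of a group of 8 heavy atoms (7 carbon, 1 nitrogen; one six-membered aromatic ring of carbon only), on an aromatic carbon is the difference between them. Within the data shown here, only one measured step bears on this change, a 1.8-fold lower number from compound 1 to compound 2 (0.25 log units; within the scatter) in size, and it exchanged one ring-bearing group for another, whereas the group entering compound 3 has no ring. That step therefore offers only weak guidance. The step expected in this assay is none beyond the scatter, and the estimated 1.1-fold higher number from compound 2 to compound 3 (0.05 log units; within the scatter) carries no firm direction. Compound 3 is estimated at 120 nM with an expected range from 25 nM to 600 nM for a typical measurement.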

Compound 3, half-maximal inhibitory concentration: 1480 nM
For compound 3 the middle estimate is 12-fold (1.09 log units) below the measured one; measured number outside the range, above it.
By their numbers in this assay, from the lowest: compounds 2 and 1 (each within the scatter of the next); then compound 3.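

At this aromatic carbon the group clearly matters: in this assay, replacing the 3-cyanophenyl group with the ring-free group gives a 14-fold higher number from compound 2 to compound 3 (1.14 log units; beyond the scatter) and makes compound 3 a weaker inhibitor. Replacing the cyanopyridine group of compound 1 points the same way, with a 7.8-fold higher number from compound 1 to compound 3 (0.89 log units; beyond the scatter). The earlier exchange of one ring-bearing group for another stayed within the scatter, so this is the first sign that the position does not accept every group equally, though no measurement shown accounts for the drop.

The compounds shown leave open whether the ring, the nitrile or the particular open-chain group drives this difference, as the ring and nitrile leave together. A plain phenyl ring without a nitrile, a morpholine ring or a simple amine at this carbon could help separate these possibilities.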